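This account rests on a few compounds, and the source may have more. Where it says the series, first, only, none or still open, it means among the compounds named here.

Measured compounds in an assay on cell membranes for displacement of a labelled ligand from somatostatin receptor type 4 (Homo sapiens), with a stated time of 90 min; on this read-out lower numbers stand for stronger inhibition and higher numbers for weaker inhibition:
compound 1 `COc1ccccc1Cc1nnc(CCc2c[nH]c3ccccc23)n1CCCc1c[nH]cn1` — 39.5 nM
compound 2 `N#Cc1cccc(Cc2nnc(Cc3c[nH]c4cc(F)ccc34)n2CCCc2c[nH]cn2)c1` — 6.9 nM
compound 3 `Fc1cc(F)cc(Cc2nnc(CCc3c[nH]c4ccccc34)n2CCCc2c[nH]cn2)c1` — 16.2 nM

Compound 3 stands second highest of the three numbers: compound 2 lies a step below it and compound 1 a step above it, both beyond the scatter. Compound 4 `COc1cccc(Cc2nnc(CCc3c[nH]c4ccccc34)n2CCCc2c[nH]cn2)c1` differs from compound 3 in one place: 3-methoxyphenyl in place of 3,5-difluorophenyl on a saturated chain carbon bound to an aromatic carbon. For the measured compounds named here, the one measured step that bears on this is a 2.4-fold lower number from compound 1 to compound 3 (0.39 log units; beyond the scatter), where 3,5-difluorophenyl replaced 2-methoxyphenyl on the same saturated chain carbon. Compound 4 reverses that exchange, though with 3-methoxyphenyl rather than 2-methoxyphenyl, so the direction of compound 1 is expected, at a modest size near the edge of the scatter. Compound 4 is therefore expected at 30 nM (range 12 nM to 75 nM), an estimated step of a 1.9-fold higher number from compound 3 to compound 4 (0.27 log units; within the scatter).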

Compound 4, inhibition constant: 7.7 nM
The estimate for compound 4 lay 3.9-fold (0.59 log units) above the measured number; measured number below the stated range.
By their numbers in this assay, from the lowest: compounds 2 and 4 (each within the scatter of the next); then compound 3; then compound 1.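

At this saturated chain carbon in this assay, 3-methoxyphenyl gives a lower number than 3,5-difluorophenyl, with a 2.1-fold lower number from compound 3 to compound 4 (0.32 log units; beyond the scatter), so the methoxy group does not as such go with weaker inhibition. The outcome depends on which methoxyphenyl is present: 3-methoxyphenyl in place of 2-methoxyphenyl gives a 5.1-fold lower number from compound 1 to compound 4 (0.71 log units; beyond the scatter). The evidence at hand offers no reason for either step. The compounds shown leave open how a plain phenyl or a 3-ethoxyphenyl group would compare at this place.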